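A few compounds are considered here, and "the series" means these few. Any claim that something is new, unique, unknown or untested is made for them only; others in the source may bear on it.

In an ADME assay on microsomes from liver (Mus musculus) for metabolic stability, read by LC-MS, with a stated time of 30 min, tested at 1 uM (a higher number here means that more of the compound is left, a lower number that less of the compound is left), compound 1 `O=C(NCc1ccc(S(=O)(=O)N2CCCCC2)cc1)c1cnc2nccn2c1` gives 0.28%, the lower of the two numbers available and close to the bottom of the scale. Compound 3 `O=C(NCc1ccc(S(=O)(=O)N2CCCCC2)cc1)c1ccc2nc[nH]c2c1` gives 16%, while compound 2 `O=C(NCc1ccc(S(=O)(=O)N2CCCCC2)cc1)c1ccn2ccnc2c1` has the entry "not determined" (no result reported) and so offers no comparison.

The next change leads to compound 4 `O=C(NCc1ccc(S(=O)(=O)c2cccc(C(F)(F)F)c2)cc1)c1cnc2nccn2c1`: 3-(trifluoromethyl)phenyl in place of piperidin-1-yl on a sulfonyl sulfur. In words, 3-(trifluoromethyl)phenyl stands in place of piperidin-1-yl on a sulfonyl sulfur.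

Among the measured compounds shown here, no measured step covers a change at the sulfonyl sulfur. For the measured compounds named here, the only measured step, a number 15.7 percentage points higher from compound 1 to compound 3 (beyond the scatter), is a change on the carbonyl carbon, so it bears only indirectly. It shows that one substitution in this series can lift the number by a modest amount. Starting this close to the bottom of the scale, any real movement in this assay can only be upward. The expected step of a number 5.7 percentage points higher from compound 1 to compound 4 (within the scatter) is therefore small and upward, no larger than the measured one, and it may stay within the scatter. The estimated value for compound 4 is 6%, with an expected range of 0% to 25%.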

Compound 4, percent of the compound remaining: 27%
Beside the measured number, compound 4's estimate is 21 percentage points below it; measured number outside the range, above it.
By their numbers in this assay, from the lowest: compound 1; then compound 3; then compound 4.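

The sulfonyl sulfur is a position where the read-out in this assay responds: 3-(trifluoromethyl)phenyl in place of piperidin-1-yl gives a number 26.7 percentage points higher from compound 1 to compound 4 (beyond the scatter), so a lift is no longer confined to the change on the carbonyl carbon. The two groups do not differ in their counted hydrogen-bond donors, hydrogen-bond acceptors or net charge, so those counts do not separate them here. No measured evidence bears on why this replacement raises the number.

The compounds shown do not separate the aromatic ring from the trifluoromethyl group, and they give no reading for a plain phenyl or a morpholin-4-yl on the sulfonyl sulfur. Among the compounds shown here, it also remains open whether this change and the one behind a number 15.7 percentage points higher from compound 1 to compound 3 (beyond the scatter) add up when combined in a single compound.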